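Shortening the chain on compound 1's ring nitrogen

The source may report more compounds than this note shows. Statements on the series, on what has been measured and on what is new or still open speak of the compounds shown alone.

For the measured compounds named here, compound 1 `CCCCCN(Cc1ccc(C(=O)NO)cc1)c1ncc(-c2ccc(C)cc2)s1` is one of two compounds measured in a functional assay on A549 cells (Homo sapiens) for antiproliferative activity, read by MTT assay, with a stated time of 48 h (on this read-out higher numbers stand for weaker inhibition of growth and lower numbers for stronger inhibition of growth), and compound 1 gives 9140 nM, the higher of the two numbers. Its neighbour, compound 2 `Cc1ccc(-c2cnc(N(CCCOc3ccccc3)Cc3ccc(C(=O)NO)cc3)s2)cc1`, in this assay gives 2530 nM. Going by the values given here, the single measured step, a 3.6-fold lower number from compound 1 to compound 2 (0.56 log units; beyond the scatter), came from placing phenoxy in place of ethyl on a saturated chain carbon, three bonds along the chain from a nitrogen on an aromatic ring.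

Compound 3 `CCCN(Cc1ccc(C(=O)NO)cc1)c1ncc(-c2ccc(C)cc2)s1` has not yet been measured. It differs from compound 1 as follows: hydrogen in place of ethyl on a saturated chain carbon, three bonds along the chain from a nitrogen on an aromatic ring. The change sits at the same place as the change from compound 1 to compound 2, but it removes the ethyl rather than replacing it with phenoxy, so that step bears on it only by location and offers no direct guide to the direction. With nothing else to go on, compound 3 is expected to stay within the scatter of compound 1 in this assay, the estimated step being a 1.3-fold higher number from compound 1 to compound 3 (0.12 log units; within the scatter). Compound 3 is therefore estimated at 12000 nM, with a range from 5000 nM to 30000 nM.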

Compound 3, concentration for 50% growth inhibition: 3310 nM
For compound 3 the middle estimate is 3.6-fold (0.56 log units) above the measured one, and the stated range ends above it.
By their numbers in this assay, from the lowest: compounds 2 and 3 (each within the scatter of the next); then compound 1.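

In this assay, cutting pentyl to propyl gives a 2.8-fold lower number from compound 1 to compound 3 (0.44 log units; beyond the scatter), so this position responds to a simple shortening of the chain and not only to the arrival of a phenoxy group. Hydrogen in place of phenoxy at the same place gives a 1.3-fold higher number from compound 2 to compound 3 (0.12 log units; within the scatter), which is within the scatter, so the phenoxy group is not needed to reach this level and the earlier step can no longer be read as a gain specific to it. Nothing on hand explains why the pentyl chain stands apart from the other two chains.

The compounds shown leave open whether a still shorter chain, such as ethyl or methyl on the same nitrogen, would lower the number further or lose ground, and whether a butyl chain would read like propyl or like pentyl. They also leave open how a chain ending in an amine or a carboxylic acid at this place would read, and whether the same order would hold on other cell lines.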